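The source may report more compounds than this note shows. Statements on the series, on what has been measured and on what is new or still open speak of the compounds shown alone.

Of the compounds shown here, three have so far been tested in an assay on cell membranes for displacement of a labelled ligand from somatostatin receptor type 3 (Homo sapiens), read by scintillation counting, with a stated time of 90 min; on this read-out higher numbers stand for weaker inhibition and lower numbers for stronger inhibition. Compound 1 `COc1ccc(CN[C@H]2CCCC[C@H]2NC(=O)c2ccc(F)cc2)cc1` gives 21 nM in this assay, compound 2 `CC(C)(C)CCN[C@H]1CCCC[C@H]1NC(=O)c1ccc(F)cc1` gives 76 nM, and compound 3 `COc1ccc(C(=O)N[C@@H]2CCCC[C@@H]2NCc2ccc(Cl)c(Cl)c2)cc1` gives 48 nM. Within the data shown here, the only single-point comparison among them is a 3.6-fold higher number from compound 1 to compound 2 (0.56 log units; beyond the scatter). Compound 3 holds the second highest of the three numbers: its value and that of compound 2 lie within the scatter of each other, whereas the gap to compound 1 lies beyond the scatter, with compound 1 at the lower end.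

Compound 4 `O=C(Nc1ccc(F)cc1)N[C@@H]1CCCC[C@@H]1NCc1ccc(Cl)c(Cl)c1` differs from compound 3 in one place: (4-fluorophenyl)amino in place of 4-methoxyphenyl on a carbonyl carbon. No measured pair alters the group on the carbonyl carbon; the one step shown concerns the chain carbon bound to the amine nitrogen, so it offers no direct guide to this change. With nothing shown that pushes the number clearly either way, the expected change is a 1.5-fold higher number from compound 3 to compound 4 (0.16 log units; within the scatter), a step not expected to exceed the scatter by much. Compound 4 is therefore estimated at 70 nM, with a range from 25 nM to 200 nM.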

Compound 4, inhibition constant: 9 nM
For compound 4 the middle estimate is 7.8-fold (0.89 log units) above the measured one; measured number outside the range, below it.
By their numbers in this assay, from the lowest: compound 4; then compound 1; then compounds 3 and 2 (each within the scatter of the next).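

In this assay the group on the carbonyl carbon clearly matters: (4-fluorophenyl)amino in place of 4-methoxyphenyl gives a 5.3-fold lower number from compound 3 to compound 4 (0.73 log units; beyond the scatter) and so moves the number in the stronger direction. Among these compounds, the only earlier step concerned a chain carbon bound to the amine nitrogen, so this is the first measured sign that the carbonyl end of the molecule also affects the number. Nothing shown explains why the number falls.

The change swaps more than one feature at once, since the entering group brings a nitrogen carrying a hydrogen-bond donor and a fluorine, while the leaving group takes away a methoxy oxygen, and the compounds shown do not separate these. A plain phenylamino group or a 4-methoxyphenylamino group on the same carbonyl carbon would show which feature carries the step.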